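Removing the benzyl from compound 2

The source may report more compounds than this note shows. Statements on the series, on what has been measured and on what is new or still open speak of the compounds shown alone.

compound 1 `CC(C)c1ccc(COc2ccccc2C2CC(=O)c3ccccc3O2)cc1` gives 23100 nM
compound 2 `O=C1CC(c2ccccc2OCc2ccccc2)Oc2ccccc21` gives 24500 nM
compound 3 `O=C1CC(c2ccccc2O)Oc2ccccc21` has not yet been measured

Among the compounds with values here, in a functional assay on J774.A1 cells (Mus musculus) for inhibition, read by immunoassay, with a stated time of 12 h (on this read-out lower numbers stand for stronger inhibition and higher numbers for weaker inhibition), compound 2 gives 24500 nM and so sits level, within the scatter, with compound 1, the only other measured compound. The change on going further is hydrogen in place of benzyl on an oxygen on an aromatic ring and in words it is hydrogen in place of benzyl on an oxygen on an aromatic ring, or benzyloxy to hydroxy.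

Within the data shown here, only one measured step bears on this, and a 1.1-fold higher number from compound 1 to compound 2 (0.03 log units; within the scatter) is small. That step put hydrogen in place of isopropyl on an aromatic carbon, while the new change removes the whole benzyl, so it is only a weak guide. Among the measured compounds shown here, no measured compound lacks the benzyl, and the data therefore point in no direction.

No change beyond the scatter is firmly expected in this assay and the estimated size, a 1.2-fold lower number from compound 2 to compound 3 (0.09 log units; within the scatter) as expected here, remains quite uncertain. For compound 3 the estimated value is 20000 nM with an expected range from 7000 nM to 60000 nM on this reasoning.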

Compound 3, half-maximal inhibitory concentration: 71300 nM
Estimate against measurement, compound 3: 3.6-fold (0.55 log units) below; measured number outside the range, above it.
By their numbers in this assay, from the lowest: compounds 1 and 2 (each within the scatter of the next); then compound 3.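

In this assay, replacing the benzyl on the oxygen with hydrogen, which leaves a hydroxy on the aromatic ring, gives a 2.9-fold higher number from compound 2 to compound 3 (0.46 log units; beyond the scatter), a modest loss of inhibition and the only step shown that lies beyond the scatter. The earlier step, a 1.1-fold higher number from compound 1 to compound 2 (0.03 log units; within the scatter), removed only the isopropyl and left the number level, so it could not show whether the rest of the benzyloxy group mattered; this new step shows that removing the whole benzyl does weaken inhibition at this position. No supporting measurement accompanies this result, so the reason for the loss remains unexplained.

The compounds shown leave open whether the benzyl itself is needed or whether a smaller group on the same oxygen, such as a methyl, or a longer alkyl chain, would keep the number close to that of compound 2. They also leave open how an amine or a carboxylic acid on the benzyl would shift the number, in either direction.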